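Fluorinated phenyl ethers: extending the series to compound 4

This account rests on a few compounds, and the source may have more. Where it says the series, first, only, none or still open, it means among the compounds named here.

Measured so far:
compound 1 `CC(C)[C@H](NC(=O)COc1cccc2ccccc12)C(=O)N[C@@H](CC(=O)O)C(=O)COc1cccc(C(F)(F)F)c1`; in a functional assay with Homo sapiens as the target (a higher number here means a weaker inhibitor, a lower number a stronger inhibitor), compound 1 gives 16600 nM
compound 2 `CC(C)[C@H](NC(=O)COc1cccc2ccccc12)C(=O)N[C@@H](CC(=O)O)C(=O)COc1ccc(C(F)(F)F)cc1`; compound 2 gives 12300 nM
compound 3 `CC(C)[C@H](NC(=O)COc1cccc2ccccc12)C(=O)N[C@@H](CC(=O)O)C(=O)COc1c(F)c(F)cc(F)c1F`; compound 3 gives 6250 nM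

Compound 1 has the highest number of the three. Compound 2 sits within the scatter of it, a 1.3-fold lower number from compound 1 to compound 2 (0.13 log units; within the scatter), whereas compound 3 lies beyond it, a 2.7-fold lower number from compound 1 to compound 3 (0.42 log units; beyond the scatter). Compound 4 `CC(C)[C@H](NC(=O)COc1cccc2ccccc12)C(=O)N[C@@H](CC(=O)O)C(=O)COc1c(F)c(F)c(F)c(F)c1F` is not yet measured. It differs from compound 1 by 2,3,4,5,6-pentafluorophenyl in place of 3-(trifluoromethyl)phenyl on an oxygen on a saturated carbon. For the measured compounds named here, the steps that bear on this change are those leading to the 2,3,5,6-tetrafluorophenyl compound 3, namely a 2.7-fold lower number from compound 1 to compound 3 (0.42 log units; beyond the scatter) and a 2.0-fold lower number from compound 2 to compound 3 (0.29 log units; within the scatter), both toward lower numbers. A step of similar size and direction is therefore expected, a 2.8-fold lower number from compound 1 to compound 4 (0.44 log units; beyond the scatter). Compound 4 is estimated at 6000 nM, with a range from 2500 nM to 14000 nM.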

Compound 4, half-maximal inhibitory concentration: 8890 nM
Beside the measured number, compound 4's estimate is 1.5-fold (0.17 log units) below it; the range from low to high includes it.
By their numbers in this assay, from the lowest: compounds 3, 4, 2 and 1 (each within the scatter of the next, the first and the last beyond it).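

In this assay, fluoro in place of hydrogen on an aromatic carbon gives no readable change at this position (a 1.4-fold higher number from compound 3 to compound 4 (0.15 log units; within the scatter)). The 2,3,4,5,6-pentafluorophenyl group also stays within the scatter of both trifluoromethyl-bearing groups (a 1.9-fold lower number from compound 1 to compound 4 (0.27 log units; within the scatter); a 1.4-fold lower number from compound 2 to compound 4 (0.14 log units; within the scatter)), so among the fluorinated groups here only compound 3 and compound 1 stand apart. No available evidence explains these values.

The compounds shown leave open whether an unsubstituted phenyl on this oxygen would differ from these fluorinated groups. Also open, as far as these compounds go, is whether a phenyl carrying an amine or a carboxylic acid would move the number beyond the scatter of compound 4.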